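Methyl to methoxy on the benzylamide ring of compound 1

This account rests on a few compounds, and the source may have more. Where it says the series, first, only, none or still open, it means among the compounds named here.

Of the compounds shown here, three sharing one core have been measured in an assay on microsomes from liver for inhibition of 3-hydroxy-3-methylglutaryl-coenzyme A reductase (Rattus norvegicus), read by scintillation counting, with stated times of 0.5 h and 0.75 h; on this read-out higher numbers stand for weaker inhibition and lower numbers for stronger inhibition. Compound 1 `Cc1ccccc1CNC(=O)c1nc(-c2ccc(F)cc2)n(CC[C@@H](O)C[C@@H](O)CC(=O)O)c1C1CC1` gives 4.9 nM in this assay, the second highest of the three numbers. Compound 2 `O=C(O)C[C@H](O)C[C@H](O)CCn1c(-c2ccc(F)cc2)nc(C(=O)NCc2cccc(F)c2)c1C1CC1` gives 1.2 nM, and compound 3 `Cc1cccc(CNC(=O)c2nc(-c3ccc(F)cc3)n(CC[C@@H](O)C[C@@H](O)CC(=O)O)c2C2CC2)c1` gives 7.2 nM. The step from compound 1 to compound 2 is a 4.1-fold lower number from compound 1 to compound 2 (0.61 log units; beyond the scatter), while the step from compound 1 to compound 3 is a 1.5-fold higher number from compound 1 to compound 3 (0.17 log units; within the scatter). Between compound 2 and compound 3 the step is a 6.0-fold higher number from compound 2 to compound 3 (0.78 log units; beyond the scatter).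

Compound 4 `COc1ccccc1CNC(=O)c1nc(-c2ccc(F)cc2)n(CC[C@@H](O)C[C@@H](O)CC(=O)O)c1C1CC1` has not yet been measured. It differs from compound 1 in one place: methoxy in place of methyl on an aromatic carbon. The shared change reads 2-methylphenyl to 2-methoxyphenyl, or 2-methylbenzyl to 2-methoxybenzyl.

Within the data shown here, none of the measured steps exchanges methyl for methoxy. The nearest comparison, the step from compound 1 to compound 3, moves the methyl without altering the group and stays within the scatter. The step from compound 2 to compound 3 replaces fluoro by methyl on an aromatic carbon and is beyond the scatter, but it is a different exchange. Little guidance is therefore available, and compound 4 is expected to sit close to compound 1 in this assay, with a step of a 1.2-fold higher number from compound 1 to compound 4 (0.09 log units; within the scatter) that lies within the scatter. Compound 4 is estimated at 6 nM, with a range from 2 nM to 18 nM.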

Compound 4, half-maximal inhibitory concentration in the 3-hydroxy-3-methylglutaryl-coenzyme A reductase assay: 7 nM
The estimate for compound 4 lay 1.2-fold (0.07 log units) below the measured number; the range from low to high includes it.
By their numbers in the 3-hydroxy-3-methylglutaryl-coenzyme A reductase assay, from the lowest: compound 2; then compounds 1, 4 and 3 (each within the scatter of the next).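

Among these compounds, in the 3-hydroxy-3-methylglutaryl-coenzyme A reductase assay compound 4 gives 7 nM, and the first exchange of the group itself, rather than a move of the methyl, is a 1.4-fold higher number from compound 1 to compound 4 (0.15 log units; within the scatter), so at this place, ortho to a large group, the added oxygen and its hydrogen-bond acceptor bring no readable difference from methyl. Compound 4 also cannot be told apart from compound 3, with a 1.0-fold lower number from compound 3 to compound 4 (0.01 log units; within the scatter), while a 5.8-fold higher number from compound 2 to compound 4 (0.77 log units; beyond the scatter) confirms that among these four compounds only compound 2, with its 3-fluorophenyl group, stands apart from the others, and neither methyl nor methoxy on this ring matches it. In a physicochemical assay for lipophilicity, using the shake flask method, at pH 7.4 (on this read-out lower numbers stand for lower lipophilicity and higher numbers for higher lipophilicity), compound 1 gives 0.44 and compound 4 gives 0.16, and the same exchange is a number 0.28 log units lower from compound 1 to compound 4 (within the scatter), so neither read-out separates methoxy from methyl at this place.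

The compounds shown leave open whether a hydroxyl or an amine at this same place would stay level with methyl and methoxy, and whether fluoro here, or methoxy in the position that the fluoro holds in compound 2, would reach the number of compound 2. Nothing given here accounts for why compound 2 stands apart from the others.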